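Furan-2-yl for 1H-pyrrol-2-yl: a repeated swap

The source may hold more compounds than are shown below. What is called first, only, known or untested is meant among the compounds shown, and "the series" means these compounds.

In a functional assay on MIA cells (Homo sapiens) for inhibition, read by MTT assay, with a stated time of 72 h (a higher number here means a weaker inhibitor of growth, a lower number a stronger inhibitor of growth), compound 1 `COc1ccc(CNC(=O)/C(C#N)=C/c2ccc[nH]2)cc1` gives a value that is only a limit of the assay, > 50000 nM. Compound 3 `COc1ccc(CNC(=O)/C(C#N)=C/c2ccco2)cc1` carries the change (furan-2-yl in place of 1H-pyrrol-2-yl on a double-bonded chain carbon bound to a double-bonded chain carbon), and in this assay compound 3 gives 34000 nM. The step is an at least 1.4-fold lower number from compound 1 to compound 3 (0.16 log units; that floor lies within the scatter), a floor that rests on (the limit of > 50000 nM in this assay, at which 2 of the 3 values shown sit). Compound 2 `N#C/C(=C\c1ccc[nH]1)C(=O)NCc1ccc(Cl)c(Cl)c1` has another core, and how it differs from the core of compound 1 is not broken down here. In this assay compound 2 gives only a limit, > 50000 nM. Compound 4 `N#C/C(=C\c1ccco1)C(=O)NCc1ccc(Cl)c(Cl)c1` is not yet measured and differs from compound 2 by the same change, (furan-2-yl in place of 1H-pyrrol-2-yl on a double-bonded chain carbon bound to a double-bonded chain carbon). In this assay the expected step is an at least 1.2-fold lower number from compound 2 to compound 4 (0.09 log units; that floor lies within the scatter), close in size to an at least 1.4-fold lower number from compound 1 to compound 3 (0.16 log units; that floor lies within the scatter). For compound 4 the estimated value is 40000 nM, with a likely range from 15000 nM to 100000 nM.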

Compound 4, concentration for 50% growth inhibition: > 50000 nM
Compound 4: a limit, no number (the forecaster's own chance of this, stated with the estimate: 45%); at least 1.2-fold (0.09 log units) between middle value and limit.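

Compound 2 and compound 4 both give only a limit, not a number, so no step can be read between them: the limit of > 50000 nM in this assay, at which 3 of the 4 values shown sit.

The compounds shown leave open whether furan-2-yl in place of 1H-pyrrol-2-yl changes growth inhibition at all on the core of compound 2.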